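The compounds below may be only part of what the source reports. "The series", "measured", "known", "first", "only" and "open" are said of these compounds alone.

Measured in a functional assay on NB1 cells (Homo sapiens) for cytotoxicity, read by MTT assay, with a stated time of 3 days; on this read-out lower numbers stand for stronger inhibition and higher numbers for weaker inhibition:
- compound 1 `N#Cc1c(O)nc(SCc2nc3ccccc3[nH]2)nc1-c1ccccc1`: 6.57 nM
- compound 2 `CCNc1nc(SCc2nc3ccccc3[nH]2)nc(-c2ccccc2)c1C#N`: 2.63 nM
- compound 3 `N#Cc1c(-c2ccccc2)nc(SCc2nc3ccccc3[nH]2)nc1N1CCNCC1`: 6.75 nM

Compound 3, at 6.75 nM, is level with compound 1 and sits above compound 2, as a 1.0-fold higher number from compound 1 to compound 3 (0.01 log units; within the scatter) and a 2.6-fold higher number from compound 2 to compound 3 (0.41 log units; beyond the scatter) show. Compound 4 `N#Cc1c(-c2ccccc2)nc(SCc2nc3ccccc3[nH]2)nc1N1CCN(S(=O)(=O)c2ccccc2)CC1` has phenylsulfonyl in place of hydrogen on an amine nitrogen in a ring. Within the data shown here, no measured compound carries a substituent on that nitrogen. Among the measured compounds shown here, the only guides are the exchanges on the aromatic carbon, which were modest at most: a 2.5-fold lower number from compound 1 to compound 2 (0.40 log units; beyond the scatter) and a 2.6-fold higher number from compound 2 to compound 3 (0.41 log units; beyond the scatter). The data therefore give no direction, and no step beyond the scatter is expected, although the group is large and the uncertainty wide. The expected change is a 1.0-fold higher number from compound 3 to compound 4 (0.02 log units; within the scatter). For compound 4 the estimated value is 7 nM, with an expected range of 2 nM to 25 nM.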

Compound 4, half-maximal inhibitory concentration: 3.28 nM
For compound 4 the middle estimate is 2.1-fold (0.33 log units) above the measured one; low and high end bracket the measured number.
By their numbers in this assay, from the lowest: compounds 2, 4, 1 and 3 (each within the scatter of the next, the first and the last beyond it).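

In this assay, among these compounds, the amine nitrogen in the six-membered ring, which no earlier compound carried a substituent on, accepts a group of this size without any loss: phenylsulfonyl in place of hydrogen gives a 2.1-fold lower number from compound 3 to compound 4 (0.31 log units; beyond the scatter). Among the compounds shown here, the earlier compounds showed only exchanges on the aromatic carbon, so this is the first sign that this nitrogen can bear a substituent. Nothing measured here accounts for the step. It remains open whether the phenyl ring or the sulfonyl link carries this change, since methylsulfonyl, benzoyl or benzyl on that nitrogen are not among the compounds shown.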